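Amine linker in place of hydroxypropoxy on the aryl group

A few compounds are considered here, and "the series" means these few. Any claim that something is new, unique, unknown or untested is made for them only; others in the source may bear on it.

Compound 3 `COc1cc(OC)c2c(=O)cc(-c3ccc(OCC(O)CN4CCCC4)cc3)oc2c1` gives 57% in a functional assay (Homo sapiens) for antiproliferative activity, read by resazurin assay, with a stated time of 48 h, tested at 20 uM (a lower number here means a weaker effect, a higher number a stronger effect of the compound at the concentration tested), the higher of the two numbers in hand. Compound 1 `COc1cc(OC)c2c(=O)cc(-c3ccc(OCCBr)cc3)oc2c1` gives 20%, and the step of a number 37 percentage points higher from compound 1 to compound 3 (beyond the scatter) is large. Compound 2 `COc1cc(OC)c2c(=O)cc(-c3ccc(OC4CCN(C)CC4)cc3)oc2c1` has no result in this assay, reported as "not determined" (no result reported).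

Compound 4 `COc1cc(OC)c2c(=O)cc(-c3ccc(NCCN4CCCC4)cc3)oc2c1` is to be measured in this assay. Against compound 3 the change is (2-(pyrrolidin-1-yl)ethyl)amino in place of 2-hydroxy-3-(pyrrolidin-1-yl)propoxy on an aromatic carbon. The pyrrolidin-1-yl group is kept; what changes is the link to the aromatic carbon, together with the hydroxyl and one chain carbon.

For the measured compounds named here, only one measured step exists, from compound 1 to compound 3, and it exchanges the whole chain beyond the oxygen while keeping the oxygen link; it does not test an amino link nor the loss of the hydroxyl. It is therefore an indirect guide only. Since the pyrrolidin-1-yl chain that carried the large gain is retained, the step of a number 7 percentage points lower from compound 3 to compound 4 (within the scatter) is expected to stay within the scatter, with wide uncertainty. Compound 4 is estimated at 50%, between 25% and 75%.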

Compound 4, a percentage reported as inhibition, at one concentration (the size of the read-out at that concentration, not a potency): 80%
The estimate for compound 4 lay 30 percentage points below the measured number, and the stated range ends below it.
By their numbers in this assay, from the lowest: compound 1; then compound 3; then compound 4.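

The link to the aromatic carbon need not be an oxygen: the (2-(pyrrolidin-1-yl)ethyl)amino chain keeps the activity of the pyrrolidine-bearing chain in this assay and adds to it, with a number 23 percentage points higher from compound 3 to compound 4 (beyond the scatter) for this exchange. The hydroxyl of 2-hydroxy-3-(pyrrolidin-1-yl)propoxy is therefore not required for this read-out at the concentration tested, and replacing 2-bromoethoxy with the new chain gives a number 60 percentage points higher from compound 1 to compound 4 (beyond the scatter) as the widest gap in hand. Nothing measured here explains the gain.

On these data alone, the amino link, the lost hydroxyl and the shorter chain all change together in this step, so their separate shares remain open. A 2-(pyrrolidin-1-yl)ethoxy chain would separate the amino link from the other two changes, while a 3-(pyrrolidin-1-yl)propylamino chain would test the chain length on the amino link.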